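Shifting the dichlorophenyl pattern in a small series

The source may report more compounds than this note shows. Statements on the series, on what has been measured and on what is new or still open speak of the compounds shown alone.

Two compounds have numbers in a functional assay on HL-60 cells (Homo sapiens) for inhibition, read by MTT assay, with a stated time of 72 h; a lower number here means a stronger inhibitor, a higher number a weaker inhibitor. Compound 1 `Cc1nc(-c2ccccc2)c(C(=O)N2CCN(c3cccc(Cl)c3Cl)CC2)o1` gives 133 nM, and compound 2 `CCc1nc(-c2cccc(F)c2)c(C(=O)N2CCN(c3cccc(Cl)c3)CC2)o1` gives 317 nM. Compound 1 therefore stands lowest of the two, with compound 2 showing the higher number, a gap that lies beyond the scatter of the assay. Compound 2 differs from compound 1 in more than one place, so the two values together say nothing about any single change.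

Compound 3 `Cc1nc(-c2ccccc2)c(C(=O)N2CCN(c3cc(Cl)cc(Cl)c3)CC2)o1` has not been measured. It differs from compound 1 as follows: 3,5-dichlorophenyl in place of 2,3-dichlorophenyl on an amine nitrogen in a ring. Going by the values given here, no pair of measured compounds shows this kind of change, so there is no step from which to read its size. With nothing to anchor it, the expected step is small to moderate and could run either way; the working guess leans toward a somewhat higher number, near or just beyond the scatter. Compound 3 is expected to give about 250 nM in this assay, within a range from 80 nM to 800 nM. This corresponds to an expected step of a 1.9-fold higher number from compound 1 to compound 3 (0.27 log units; within the scatter), modest and uncertain in sign.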

Compound 3, half-maximal inhibitory concentration: 41.8 nM
For compound 3 the middle estimate is 6.0-fold (0.78 log units) above the measured one; measured number outside the range, below it.
By their numbers in this assay, from the lowest: compound 3; then compound 1; then compound 2.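

Going by these compounds alone, the first readable step sits on the amine nitrogen of the six-membered ring, where 3,5-dichlorophenyl in place of 2,3-dichlorophenyl gives a 3.2-fold lower number from compound 1 to compound 3 (0.50 log units; beyond the scatter) in this assay and the rest of the molecule stays the same. The two groups match in heavy atoms, ring type, hydrogen-bond donors and acceptors, and net charge, so for this pair the number follows the arrangement of the two chlorines on the ring and not any change in those counts. No measurement shown here explains the size or direction of this step.

On these data alone, the step is read on the core of compound 1 alone, so it remains open whether it would carry over with an ethyl chain and a fluorophenyl group on the core, as in compound 2, which differs from the others in more than one place. Also open, as far as these compounds go, is how far the same position tolerates other substitution, for example 3,5-dimethoxyphenyl, 3,5-dimethylphenyl or a pyridine ring in place of the dichlorophenyl group.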